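From 4-methylpiperazin-1-yl to ethoxy on a shared core

This account rests on a few compounds, and the source may have more. Where it says the series, first, only, none or still open, it means among the compounds named here.

Measured in a functional assay on A549 cells (Homo sapiens) for inhibition, read by MTT assay, with a stated time of 72 h; a higher number here means a weaker inhibitor, a lower number a stronger inhibitor:
- Compound 1 `CC(C)(C)n1cc2c(n1)C(=O)CC1(CCN(C(=O)c3cc(-c4ccc(F)cc4)nc4ccccc34)CC1)O2`: 5770 nM
- Compound 2 `CC(C)(C)n1cc2c(n1)C(=O)CC1(CCN(C(=O)c3cc(-c4ccc(N)cc4)nc4ccccc34)CC1)O2`: 970 nM
- Compound 3 `CN1CCN(c2cc(C(=O)N3CCC4(CC3)CC(=O)c3nn(C(C)(C)C)cc3O4)c3ccccc3n2)CC1`: > 10000 nM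

Compound 3 is not a number but sits at the limit of > 10000 nM in this assay, at which 1 of the 3 values shown sits. Compound 4 `CCOc1cc(C(=O)N2CCC3(CC2)CC(=O)c2nn(C(C)(C)C)cc2O3)c2ccccc2n1` has ethoxy in place of 4-methylpiperazin-1-yl on an aromatic carbon, next to the ring nitrogen: ethoxy in place of 4-methylpiperazin-1-yl on an aromatic carbon. Two measured steps put 4-methylpiperazin-1-yl on this same carbon: an at least 1.7-fold higher number from compound 1 to compound 3 (0.23 log units; that floor lies within the scatter), and an at least 10-fold higher number from compound 2 to compound 3 (1.01 log units; beyond the scatter). Changing the group there can matter, as a 5.9-fold lower number from compound 1 to compound 2 (0.77 log units; beyond the scatter) shows. Ethoxy itself is untested, so compound 1 at 5770 nM serves as a rough guide. The expected step is an at least 1.6-fold lower number from compound 3 to compound 4 (0.22 log units; that floor lies within the scatter), modest and uncertain in size. The estimate for compound 4 is 6000 nM, within an expected range of 2500 nM to 10000 nM.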

Compound 4, half-maximal inhibitory concentration: > 10000 nM
Compound 4: a limit, no number; the forecaster's own chance of this, stated with the estimate: 30%; middle value at least 1.6-fold (0.22 log units) away from the limit.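

In this assay, compound 4 gives > 10000 nM, a limit and not a number, so the step from compound 3 cannot be read. Ethoxy in place of 4-aminophenyl gives an at least 10-fold higher number from compound 2 to compound 4 (1.01 log units; beyond the scatter), while ethoxy in place of 4-fluorophenyl gives an at least 1.7-fold higher number from compound 1 to compound 4 (0.23 log units; that floor lies within the scatter). Two groups without an aromatic ring, 4-methylpiperazin-1-yl in compound 3 and ethoxy in compound 4, now sit at the same limit: the limit of > 10000 nM in this assay, at which 2 of the 4 values shown sit.

The compounds shown leave open how an unsubstituted phenyl or a hydroxyl-bearing phenyl on this carbon would read in this assay. Also open, on these data alone, is how far apart compound 3 and compound 4 truly lie.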